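The source may hold more compounds than are shown below. What is called first, only, known or untested is meant among the compounds shown, and "the series" means these compounds.

Three compounds have numbers in a functional assay on Jurkat cells (Homo sapiens) for inhibition, read by MTT assay, with a stated time of 72 h; on this read-out higher numbers stand for weaker inhibition and lower numbers for stronger inhibition. Compound 1 `COc1cccc(/C=C/C(=O)Nc2cc(OC)c(OC)c(OC)c2)c1` gives 12500 nM, compound 2 `COc1cc(NC(=O)/C=C/c2cccc(OCc3ccccc3)c2)cc(OC)c1OC` gives 3500 nM, and compound 3 `C=C(Br)C(=O)Nc1cccc(/C=C/C(=O)Nc2cccc(F)c2)c1` gives 1000 nM. Compound 3 thus has the lowest number of the three and the strongest inhibition among them, and the gaps to both others lie beyond the scatter.

Compound 4 `C=C(Br)C(=O)Nc1cccc(/C=C/C(=O)Nc2ccc(OC)cc2)c1` has not yet been measured. It differs from compound 3 in one place, with 4-methoxyphenyl in place of 3-fluorophenyl on an amide-type nitrogen.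

Going by the values given here, the only measured step between compounds that differ in one place is a 3.6-fold lower number from compound 1 to compound 2 (0.55 log units; beyond the scatter), a modest change. It arises at another place, a saturated chain carbon bound to an oxygen on an aromatic ring. Among the compounds with values here, no measured pair shows what a change of the group on the amide-type nitrogen does, so this step suggests only a rough size and no direction.

In this assay no step beyond the scatter is therefore expected, and the estimated step is a 1.5-fold higher number from compound 3 to compound 4 (0.18 log units; within the scatter). The expected value for compound 4 is 1500 nM. Its estimated range runs from 450 nM to 5000 nM.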

Compound 4, half-maximal inhibitory concentration: 470 nM
The estimate for compound 4 lay 3.2-fold (0.50 log units) above the measured number; low and high end bracket the measured number.
By their numbers in this assay, from the lowest: compound 4; then compound 3; then compound 2; then compound 1.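

In this assay, going by these compounds alone, putting 4-methoxyphenyl in place of 3-fluorophenyl on the amide-type nitrogen gives a 2.1-fold lower number from compound 3 to compound 4 (0.33 log units; beyond the scatter), the first measured change at this position, and it shows that inhibition here responds to the group on that nitrogen and that this swap moves towards stronger inhibition. Within the data shown here, the only earlier step, a 3.6-fold lower number from compound 1 to compound 2 (0.55 log units; beyond the scatter), lay at a saturated chain carbon elsewhere and could give no direction for this place. Nothing shown here explains the gain, and no measurement bears on why the entering group does better than the leaving one.

The single step changes both the substituent and its place on the phenyl ring, as the two group names show, so the compounds shown cannot separate these two changes; 4-fluorophenyl or 3-methoxyphenyl on the same nitrogen would be needed to tell them apart. As far as these compounds go, it also remains open whether the direction would hold for other groups at this position, such as an unsubstituted phenyl, a 4-aminophenyl or a 4-carboxyphenyl, since two compounds define no trend.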